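The source may hold more compounds than are shown below. What is called first, only, known or untested is meant among the compounds shown, and "the series" means these compounds.

Measured compounds in a functional assay (trachea) for antagonist activity, with Cavia porcellus as the target; on this read-out higher numbers stand for higher potency (the scale is a negative logarithm) and lower numbers for lower potency:

compound 1, `COc1cc(C(=O)NS(=O)(=O)c2ccccc2OC)ccc1Cn1ccc2ccc(NC(=O)CC3CCCC3)cc21`: 9.7
compound 2, `COc1cc(C(=O)NS(=O)(=O)c2cccs2)ccc1Cn1ccc2ccc(NC(=O)CC3CCCC3)cc21`: 9.6
compound 3, `COc1cc(C(=O)NS(=O)(=O)c2ccccc2C)ccc1Cn1ccc2ccc(NC(=O)CC3CCCC3)cc21`: 9.9

The three compounds share one core and differ only in the group on the sulfonyl sulfur. All three numbers sit close together: the step of a number 0.10 log units lower from compound 1 to compound 2 (within the scatter) is within the scatter, as is a number 0.20 log units higher from compound 1 to compound 3 (within the scatter) and a number 0.30 log units higher from compound 2 to compound 3 (within the scatter). Compound 3 therefore cannot be separated from compound 1 or compound 2 on these numbers; the three aryl groups tried so far on the sulfonyl sulfur give the same read-out within the usual scatter.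

Compound 4, `COc1cc(C(=O)NS(=O)(=O)c2c(C)cccc2Cl)ccc1Cn1ccc2ccc(NC(=O)CC3CCCC3)cc21`, has not yet been measured. It differs from compound 3 by chloro in place of hydrogen on an aromatic carbon. Going by the values given here, no measured step introduces a chloro group; the nearest information is the set of three exchanges of the whole sulfonyl aryl group, each of which moved the read-out by less than the scatter. On that basis the added chloro on the 2-methylphenyl ring is expected to leave this assay unchanged beyond the scatter, and the step of no change at the digits printed from compound 3 to compound 4 (within the scatter) is estimated to be negligible. For compound 4 the expected value in this assay is 9.9, with an estimated range from 9.4 to 10.4.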

Compound 4, negative logarithm of the antagonist equilibrium constant: 8.8
For compound 4 the middle estimate is 1.10 log units above the measured one; the whole stated range lies above it.
By their numbers in this assay, from the lowest: compound 4; then compounds 2, 1 and 3 (each within the scatter of the next).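

In this assay, going by these compounds alone, the sulfonyl aryl group no longer looks like a position that tolerates every change: chloro in place of hydrogen on the 2-methylphenyl ring, ortho to a large group and meta to a methyl group, gives a number 1.10 log units lower from compound 3 to compound 4 (beyond the scatter) and is the first step beyond the scatter. The other two exchanges ending in 2-chloro-6-methylphenyl point the same way, with a number 0.80 log units lower from compound 2 to compound 4 (beyond the scatter) and a number 0.90 log units lower from compound 1 to compound 4 (beyond the scatter) on the same read-out, so compound 4 stands apart while compounds 1, 2 and 3 remain within the scatter of one another. The data shown offer no measurement that bears on the reason for this step.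

As far as these compounds go, it remains open whether the step belongs to chloro as such or to any second group at this place on the 2-methylphenyl ring, which a fluoro, methyl or methoxy group there would help to separate. A 2-chlorophenyl group on the sulfonyl sulfur would show whether chloro gives a similar step without the methyl group.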